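Benzylic aryl swap in the rhodanine-acetic acid series

The compounds below may be only part of what the source reports. "The series", "measured", "known", "first", "only" and "open" are said of these compounds alone.

Measured so far:
- compound 1, `O=C(O)CN1C(=O)/C(=C/c2nc3ccccc3n2Cc2ccc(Br)cc2F)SC1=S`: in a functional assay on HeLa cells (Homo sapiens) for cytotoxicity, read by MTT assay, with a stated time of 48 h (on this read-out lower numbers stand for stronger inhibition and higher numbers for weaker inhibition), compound 1 gives > 50000 nM, which is a limit of the assay and not a number.
- compound 2, `Cc1ccc(Cn2c(/C=C3\SC(=S)N(CC(=O)O)C3=O)nc3ccccc32)cc1`: in this assay compound 2 gives 1280 nM.

Compound 2 holds the only number shown; the other value is a limit (the limit of > 50000 nM in this assay, at which 1 of the 2 values shown sits). For the measured compounds named here, the one measured step, an at least 39-fold lower number from compound 1 to compound 2 (1.59 log units; beyond the scatter), concerns the same place as the change now considered, so that place is sensitive. Compound 3, `COc1cc(Cn2c(/C=C3\SC(=S)N(CC(=O)O)C3=O)nc3ccccc32)cc(OC)c1`, differs from compound 2 as follows: 3,5-dimethoxyphenyl in place of 4-methylphenyl on a saturated chain carbon bound to an aromatic nitrogen. Going by the values given here, no measured pair tells the direction of a shift from 4-methylphenyl to 3,5-dimethoxyphenyl, and the aryl change seen so far went from a limit to a number, so its size is only bounded below. Compound 3 is therefore expected near compound 2, with a wide range, estimated at 2500 nM between 600 nM and 15000 nM, corresponding to an expected step of a 2.0-fold higher number from compound 2 to compound 3 (0.29 log units; within the scatter).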

Compound 3, half-maximal inhibitory concentration: 17700 nM
Compound 3: middle estimate off by 7.1-fold (0.85 log units), on the low side, and the stated range ends below it.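

In this assay the saturated chain carbon bound to an aromatic nitrogen now shows a large aryl effect with a number at both ends, a 14-fold higher number from compound 2 to compound 3 (1.14 log units; beyond the scatter), so the sensitivity of this place is measured and no longer only bounded. Compound 2 has the lowest number of the three, its steps to both others being beyond the scatter, while 3,5-dimethoxyphenyl still stands apart from 4-bromo-2-fluorophenyl, with an at least 2.8-fold lower number from compound 1 to compound 3 (0.45 log units; beyond the scatter). Compound 1 stands at a limit of the assay and not at a number, so that last step is only a bound: the limit of > 50000 nM in this assay, at which 1 of the 3 values shown sits.

The compounds shown leave open whether the higher number of compound 3 goes with the methoxy groups themselves or with their number and placing. On these data alone, how an unsubstituted phenyl or a 4-methoxyphenyl would read at this place also stays open.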